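Swapping Fluoro for Methyl on a Sulfonamide Inhibitor

The source may hold more compounds than are shown below. What is called first, only, known or untested is meant among the compounds shown, and "the series" means these compounds.

Measured compounds:
compound 1 `NS(=O)(=O)c1ccc(CNC(=O)c2ccccc2)cc1`: 4450 nM
compound 2 `Cc1ccc(S(=O)(=O)Nc2ccc(S(N)(=O)=O)cc2)cc1`: 14500 nM
compound 3 `CCOc1ccc(NS(=O)(=O)c2ccc(F)cc2)cc1`: 720 nM

All three were tested in an assay on isolated protein for inhibition of Intestinal-type alkaline phosphatase (Bos taurus), read by chemiluminescence and spectrophotometry; on this read-out higher numbers stand for weaker inhibition and lower numbers for stronger inhibition. Compound 3 gives the lowest number of the three, so it inhibits most strongly; the gap to compound 1 is beyond the usual scatter, and the gap to compound 2 is larger still, also beyond the scatter. No pair of these compounds differs in a single place, so no measured step tells how one small change shifts the number.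

Compound 4 `CCOc1ccc(NS(=O)(=O)c2ccc(C)cc2)cc1` is the next compound to be measured. It differs from compound 3 in one place: methyl in place of fluoro on an aromatic carbon. Among the compounds with values here, no measured pair here shows what such a swap does, so the expectation rests on compound 3 alone, which gives 720 nM in this assay. The step of a 1.3-fold higher number from compound 3 to compound 4 (0.10 log units; within the scatter) is expected to be small, most likely within the usual scatter, with no clear direction. Compound 4 is therefore estimated to give 900 nM, with a range from 300 nM to 2700 nM.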

Compound 4, half-maximal inhibitory concentration: 30100 nM
Compound 4: the middle estimate sits 33-fold (1.52 log units) below what was measured; measured number above the stated range.
By their numbers in this assay, from the lowest: compound 3; then compound 1; then compound 2; then compound 4.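

The aromatic carbon para to a large group proves very sensitive in this assay and a single exchange there, methyl in place of fluoro, gives a 42-fold higher number from compound 3 to compound 4 (1.62 log units; beyond the scatter) with no change in ring, charge or counted hydrogen-bond donors and acceptors. Ethoxy in place of sulfamoyl on an aromatic carbon gives only a 2.1-fold higher number from compound 2 to compound 4 (0.32 log units; beyond the scatter) as a modest step, so carrying ethoxy does not by itself secure a low number. Nothing measured here explains the size of the step from fluoro to methyl.

As far as these compounds go, it remains open whether fluoro is specifically favourable at this place or methyl specifically unfavourable. A bare hydrogen, chloro or methoxy on the same aromatic carbon would help separate these two readings.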